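A few compounds are considered here, and "the series" means these few. Any claim that something is new, unique, unknown or untested is made for them only; others in the source may bear on it.

Working notes on the series. Compound 1 `CCc1ccc(N2C(=O)/C(=C/c3ccc(N(C)C)cc3)N(C)C2=S)cc1` and compound 2 `CN1C(=S)N(c2ccc3c(c2)CCC3)C(=O)/C1=C/c1cccc(O)c1O` share the core and differ both in the aryl group on the thiohydantoin nitrogen and in the arylidene group. In an assay for inhibition of NADPH oxidase 4 (Homo sapiens), read by chemiluminescence (on this read-out lower numbers stand for stronger inhibition and higher numbers for weaker inhibition), compound 1 gives 2630 nM, and in this assay compound 2 gives 2360 nM. Compound 2 has the lower of the two numbers, but compound 1 sits within the scatter of it, so no order between the two can be read.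

Compound 3 `CN1C(=S)N(c2ccc3c(c2)CCC3)C(=O)/C1=C/c1ccc(N(C)C)cc1` keeps the core of compound 2 and carries the change (4-(dimethylamino)phenyl in place of 2,3-dihydroxyphenyl on a double-bonded chain carbon bound to a double-bonded ring carbon), which brings in the same arylidene group that compound 1 carries. For the measured compounds named here, no step between two measured compounds that differ in one place is available for this change. Since compound 1, with that group on its own core, gives 2630 nM, no step beyond the scatter is expected in this assay, in either direction. Compound 3 is estimated at 2700 nM, within 1200 nM to 6000 nM; this corresponds to an expected step of a 1.1-fold higher number from compound 2 to compound 3 (0.06 log units; within the scatter).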

Compound 3, inhibition constant: 13100 nM
Compound 3: middle estimate off by 4.9-fold (0.69 log units), on the low side; the whole stated range lies below it.
By their numbers in this assay, from the lowest: compounds 2 and 1 (each within the scatter of the next); then compound 3.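

On the core of compound 2, in this assay, 4-(dimethylamino)phenyl in place of 2,3-dihydroxyphenyl on a double-bonded chain carbon bound to a double-bonded ring carbon gives a 5.6-fold higher number from compound 2 to compound 3 (0.74 log units; beyond the scatter); the group at this position therefore counts once the rest is held fixed, which compound 1 and compound 2, differing in two places, could not show. With 4-(dimethylamino)phenyl held fixed, 2,3-dihydro-1H-inden-5-yl in place of 4-ethylphenyl on an amide-type nitrogen in a ring gives a 5.0-fold higher number from compound 1 to compound 3 (0.70 log units; beyond the scatter), so the group on that nitrogen counts as well. No measurement in hand explains either step.

Still open is whether both hydroxyl groups of the 2,3-dihydroxyphenyl group are needed, as a phenyl carrying a single hydroxyl is not among the compounds shown. Also open, going by these compounds, is how 4-ethylphenyl behaves alongside 2,3-dihydroxyphenyl on the shared core.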